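Side-chain heteroaryl swap on the chain carbon

A few compounds are considered here, and "the series" means these few. Any claim that something is new, unique, unknown or untested is made for them only; others in the source may bear on it.

Values in an assay on CHO cells for displacement of a labelled ligand from prostaglandin E2 receptor EP3 subtype (Homo sapiens), read by radioligand binding (a lower number here means a stronger inhibitor, a higher number a weaker inhibitor), for the measured compounds:
compound 1 `CC(C)C(c1ccc(-c2ccc3cccc(F)c3c2)[nH]c1=O)N1CCNC1=O`: 9.1 nM
compound 2 `CC(C)C(CC(N)=O)c1ccc(-c2ccc3cccc(F)c3c2)[nH]c1=O`: 5 nM
compound 3 `CC(C)C(Nc1nnc[nH]1)c1ccc(-c2ccc3cccc(F)c3c2)[nH]c1=O`: 22 nM

Compound 3 has the highest number of the three: from compound 1 the step is a 2.4-fold higher number from compound 1 to compound 3 (0.38 log units; beyond the scatter), from compound 2 it is a 4.4-fold higher number from compound 2 to compound 3 (0.64 log units; beyond the scatter); compound 1 to compound 2 moves a 1.8-fold lower number from compound 1 to compound 2 (0.26 log units; within the scatter). Compound 4 `Cc1c[nH]c(C(c2ccc(-c3ccc4cccc(F)c4c3)[nH]c2=O)C(C)C)n1` differs from compound 3 by 4-methyl-1H-imidazol-2-yl in place of (4H-1,2,4-triazol-3-yl)amino on a saturated chain carbon bound to an aromatic carbon and a saturated chain carbon. All measured steps change the group at this same chain carbon and all are modest in size, with none involving the entering group itself. A modest step is therefore expected for compound 4 in this assay, most likely toward a lower number, as a 1.8-fold lower number from compound 3 to compound 4 (0.26 log units; within the scatter). Compound 4 is estimated at 12 nM, with a range from 4 nM to 40 nM.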

Compound 4, inhibition constant in the prostaglandin E2 receptor EP3 subtype assay: 12 nM
Compound 4: middle estimate and measured number agree at the digits printed; the range from low to high includes it.
By their numbers in the prostaglandin E2 receptor EP3 subtype assay, from the lowest: compounds 2, 1, 4 and 3 (each within the scatter of the next, the first and the last beyond it).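

In the prostaglandin E2 receptor EP3 subtype assay, 4-methyl-1H-imidazol-2-yl can stand at this chain carbon in place of (4H-1,2,4-triazol-3-yl)amino (a 1.8-fold lower number from compound 3 to compound 4 (0.26 log units; within the scatter)) or 2-oxoimidazolidin-1-yl (a 1.3-fold higher number from compound 1 to compound 4 (0.12 log units; within the scatter)) with no readable change, while carbamoylmethyl stays apart from it (a 2.4-fold higher number from compound 2 to compound 4 (0.38 log units; beyond the scatter)). In a physicochemical assay for solubility, in phosphate buffer, measured as kinetic solubility (a lower number here means a less soluble compound, a higher number a more soluble compound), compound 3 gives 17200 nM and compound 4 gives 15200 nM, so the two stand level (a 1.1-fold lower number from compound 3 to compound 4 (0.05 log units; within the scatter)). Nothing at hand explains these steps. Open, going by these compounds, is how an amine or a carboxylic acid on this chain carbon would read in either assay, and whether the methyl of the 4-methyl-1H-imidazol-2-yl group plays any part.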